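A few compounds are considered here, and "the series" means these few. Any claim that something is new, unique, unknown or untested is made for them only; others in the source may bear on it.

Measured in an ADME assay on the whole organism for pharmacokinetics, with Mus musculus as the target, at a dose of 10 mg/kg by the oral route; a lower number here means less compound in the circulation, a higher number more compound in the circulation at the dose given:
- compound 1 `CC/C(=C(/c1ccc(/C=C/C(=O)O)cc1)c1ccc2[nH]ncc2c1)c1cccc(Cl)c1`: 11000 ng.h/mL
- compound 2 `CC/C(=C(/c1ccc(/C=C/C(=O)O)cc1)c1ccc2[nH]ncc2c1)c1ccccc1C#N`: 200 ng.h/mL
- compound 3 `CC/C(=C(/c1ccc(/C=C/C(=O)O)cc1)c1ccc2[nH]ncc2c1)c1ccc(C#N)cc1C`: 4300 ng.h/mL

Compound 3, at 4300 ng.h/mL, is second highest of the three in this assay. Its gap on the upper side is a 2.6-fold lower number from compound 1 to compound 3 (0.41 log units; beyond the scatter), and on the lower side it is a 22-fold higher number from compound 2 to compound 3 (1.33 log units; beyond the scatter).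

In compound 4 `CC/C(=C(/c1ccc(/C=C/C(=O)O)cc1)c1ccc2[nH]ncc2c1)c1ccncc1C`, 3-methylpyridin-4-yl takes the place of 4-cyano-2-methylphenyl on a double-bonded chain carbon bound to a double-bonded chain carbon and a saturated chain carbon: 3-methylpyridin-4-yl in place of 4-cyano-2-methylphenyl on a double-bonded chain carbon bound to a double-bonded chain carbon and a saturated chain carbon.

All three measured steps are changes at this same place, so all bear on the new one. They are uneven: a 55-fold lower number from compound 1 to compound 2 (1.74 log units; beyond the scatter) is large, while a 2.6-fold lower number from compound 1 to compound 3 (0.41 log units; beyond the scatter) is modest. The nitrile does not sort the values, since compound 2 and compound 3 both carry one and stand far apart. Among the compounds with values here, no measured compound has a hetero atom in the ring at this place, so the direction rests on little and the range has to stay wide.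

A small drop, not clearly beyond the scatter, is expected, as a 1.7-fold lower number from compound 3 to compound 4 (0.24 log units; within the scatter). For compound 4 the estimated value is 2500 ng.h/mL, with an expected range of 400 ng.h/mL to 9000 ng.h/mL.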

Compound 4, area under the concentration-time curve: 81 ng.h/mL
The estimate for compound 4 lay 31-fold (1.49 log units) above the measured number; measured number below the stated range.
By their numbers in this assay, from the lowest: compound 4; then compound 2; then compound 3; then compound 1.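

In this assay the ring at this place proves able to take the number to the bottom of the set, and the only ring with a hetero atom gives the lowest value of the four: the change shows a 140-fold lower number from compound 1 to compound 4 (2.13 log units; beyond the scatter) and also a 2.5-fold lower number from compound 2 to compound 4 (0.39 log units; beyond the scatter) so even the poor 2-cyanophenyl member stands above it. The methyl on the ring does not hold the number up, since the swap of 4-cyano-2-methylphenyl for 3-methylpyridin-4-yl keeps a methyl and still gives a 53-fold lower number from compound 3 to compound 4 (1.72 log units; beyond the scatter) and a large step at this place therefore does not need the 2-cyanophenyl group seen earlier. The measurements at hand give no reason for this fall.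

That last step removes the nitrile and brings in the ring nitrogen in one move, so the two cannot be told apart here; a plain 2-methylphenyl at this place would separate them. From the compounds shown here alone, whether the low number belongs to this ring nitrogen in general stays open, and a pyridine ring carrying chlorine in place of the methyl would test it against the 3-chlorophenyl of compound 1.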